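Swapping nitro for fluoro on a chalcone scaffold

The source may report more compounds than this note shows. Statements on the series, on what has been measured and on what is new or still open speak of the compounds shown alone.

Two chalcones share a trimethoxy-type core and differ at the far aromatic ring. Compound 1 `COc1cc(O)c(C(=O)/C=C/c2ccc(F)cc2)c(OC)c1` carries fluoro there and a free hydroxy on the core, and in an ADME assay on cells (Fibroblast, Homo sapiens) for cytotoxicity, with a stated time of 48 h (on this read-out higher numbers stand for weaker inhibition and lower numbers for stronger inhibition), compound 1 gives > 20000 nM, which is a limit of the assay rather than a number. For the measured compounds named here, compound 2 `COc1cc(OC)c(C(=O)/C=C/c2ccc([N+](=O)[O-])cc2)c(OC)c1` carries nitro instead and in this assay compound 2 gives 7300 nM, the only numerical value so far. The value of compound 1 is a limit, not a number: the limit of > 20000 nM in this assay, at which 1 of the 2 values shown sits. Compound 3 `COc1cc(OC)c(C(=O)/C=C/c2ccc(F)cc2)c(OC)c1` keeps the fully methylated core of compound 2 but takes the fluoro of compound 1: fluoro in place of nitro on an aromatic carbon. A step toward weaker inhibition, larger than the scatter, is expected because compound 1 with the same fluoro gives > 20000 nM. For compound 3 the estimated step is a 2.2-fold higher number from compound 2 to compound 3 (0.34 log units; beyond the scatter). Compound 3 is therefore expected to give about 16000 nM, within a range from 6000 nM to 40000 nM.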

Compound 3, half-maximal inhibitory concentration: > 20000 nM
Compound 3 ended at the assay's limit (the forecaster's own chance of this, stated with the estimate: 45%); at least 1.2-fold (0.09 log units) between middle value and limit.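

With both compounds on the same fully methylated core, the group at this position can now be judged alone: fluoro in place of nitro on an aromatic carbon gives an at least 2.7-fold higher number from compound 2 to compound 3 (0.43 log units; beyond the scatter). At this place, para to a large group, nitro therefore goes with the stronger inhibition of the pair, which compound 1 and compound 2 could not show, as they differ in more than one place. The size of this step is only a minimum, and the step for methyl in place of hydrogen on the core oxygen cannot be read, as compound 1 and compound 3 both sit at a limit: the limit of > 20000 nM in this assay, at which 2 of the 3 values shown sit.

As far as these compounds go, whether an amine or a carboxylic acid at this position would give a readable number stays open. Also open, from the compounds shown here alone, is how far beyond the limit compound 3 lies, and whether the free hydroxy of compound 1 changes anything.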